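Cytotoxicity notes: chloro for methyl on compound 2

The compounds below may be only part of what the source reports. "The series", "measured", "known", "first", "only" and "open" are said of these compounds alone.

The series is compared in a functional assay on HeLa cells (Homo sapiens) for cytotoxicity, read by MTT assay, with a stated time of 72 h; on this read-out higher numbers stand for weaker inhibition and lower numbers for stronger inhibition. Compound 1 `Cc1nnc(Sc2c(C)oc3ccccc3c2=O)o1` reaches only a limit there; in this assay compound 1 gives > 50000 nM. Compound 2 `Cc1ccc2oc(CSc3nc4nc(C)cc(C)n4n3)cc(=O)c2c1` likewise reaches only a limit, and in this assay compound 2 gives > 25000 nM. Compound 3 `Cc1cc(O)cc2oc(=O)cc(CSc3nc4ccccc4[nH]3)c12` also stands at a limit, with > 25000 nM in this assay. Among the compounds with values here, compound 2 therefore cannot be placed relative to the others: all three values shown are limits, namely the limit of > 25000 nM in this assay, at which 2 of the 3 values shown sit, and (the limit of > 50000 nM in this assay, at which 1 of the 3 values shown sits), and no step between measured compounds can be stated.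

Compound 4 `Cc1cc(C)n2nc(SCc3cc(=O)c4cc(Cl)ccc4o3)nc2n1` differs from compound 2 by chloro in place of methyl on an aromatic carbon. Within the data shown here, no measured step covers this kind of change. With compound 2 at a limit, the change is expected to give no step beyond the scatter, and compound 4 is expected to return a limit again in this assay rather than a number. The estimate for compound 4 is 30000 nM, within 10000 nM to 100000 nM. The expected step is a step that the limit leaves unreadable from compound 2 to compound 4.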

Compound 4, half-maximal inhibitory concentration: > 25000 nM
Compound 4 was reported as a limit; the forecaster's own chance of this, stated with the estimate: 80%; the middle value does not contradict the limit.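

Compound 2 and compound 4 both stand at a limit in this assay, so no step can be read for chloro in place of methyl on an aromatic carbon: the limit of > 25000 nM in this assay, at which 3 of the 4 values shown sit.

The compounds shown leave open whether this change alters cytotoxicity in this assay at all, since none of them gives a number.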